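Nitro-for-chloro swap on the sulfonyl aryl group

The compounds below may be only part of what the source reports. "The series", "measured", "known", "first", "only" and "open" are said of these compounds alone.

Compound 1 `CCOC(=O)c1oc2ccc(NS(=O)(=O)c3ccccc3C)cc2c1C`, compound 2 `CCOC(=O)c1oc2ccc(NS(=O)(=O)c3ccc(Cl)cc3)cc2c1C` and compound 3 `CCOC(=O)c1oc2ccc(NS(=O)(=O)c3ccc(C(F)(F)F)cc3)cc2c1C` share one core and differ only in the aryl group on the sulfonyl sulfur. In a functional assay on MCF7 cells (Homo sapiens) for antiproliferative activity, read by MTT assay, with a stated time of 72 h (on this read-out higher numbers stand for weaker inhibition and lower numbers for stronger inhibition), compound 1 gives 105000 nM, compound 2 gives 81200 nM and compound 3 gives 48700 nM. The number for compound 2 is the second highest of the three, but its gaps to compound 1 and to compound 3 are both within the scatter, so the three are not separated. The measured steps are a 1.3-fold lower number from compound 1 to compound 2 (0.11 log units; within the scatter) and a 1.7-fold lower number from compound 2 to compound 3 (0.22 log units; within the scatter). Compound 4 `CCOC(=O)c1oc2ccc(NS(=O)(=O)c3cccc([N+](=O)[O-])c3)cc2c1C` arises from compound 2 by 3-nitrophenyl in place of 4-chlorophenyl on a sulfonyl sulfur. Both measured steps alter the aryl group on the sulfonyl sulfur, as this change does, and neither moved the number beyond the scatter; no step beyond the scatter is therefore expected in this assay. For compound 4 the expected value is 70000 nM, with a range from 30000 nM to 160000 nM. The step this estimate implies is a 1.2-fold lower number from compound 2 to compound 4 (0.06 log units; within the scatter).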

Compound 4, half-maximal inhibitory concentration: 74800 nM
Estimate against measurement, compound 4: 1.1-fold (0.03 log units) below, and the stated range covers the measured number.
By their numbers in this assay, from the lowest: compounds 3, 4, 2 and 1 (each within the scatter of the next, the first and the last beyond it).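

At the sulfonyl sulfur, 3-nitrophenyl brings 2 hydrogen-bond acceptors where 4-chlorophenyl has 0, yet this assay shows only a 1.1-fold lower number from compound 2 to compound 4 (0.04 log units; within the scatter). Against 2-methylphenyl, the change gives a 1.4-fold lower number from compound 1 to compound 4 (0.15 log units; within the scatter), so this nitro-bearing aryl group is not separated from either group. Nothing available explains why these steps stay so small.

Still open, on these data alone, is whether an amine or a carboxylic acid on this aryl ring would give a step beyond the scatter. Replacing the ring with a longer alkyl chain on the sulfonyl sulfur is equally unresolved.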